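Bromo to trifluoromethyl on the thiourea aryl group

The source may hold more compounds than are shown below. What is called first, only, known or untested is meant among the compounds shown, and "the series" means these compounds.

Of the compounds shown here, two from this series have been measured in a functional assay on HL-60 cells (Homo sapiens) for antiproliferative activity, with a stated time of 24 h; a lower number here means a stronger inhibitor, a higher number a weaker inhibitor. Compound 1 `NC(=O)c1c(NC(=O)c2ccccc2Cl)sc2c1CCN(C(=S)Nc1ccccc1C(F)(F)F)C2` gives 10600 nM in this assay. Compound 2 `Cc1ccccc1C(=O)Nc1sc2c(c1C(N)=O)CCN(C(=S)Nc1ccccc1Br)C2` gives 45200 nM in this assay, the higher of the two numbers, and the gap between the two lies beyond the usual scatter. The two compounds differ in more than one place, so neither difference alone can be credited with the gap.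

Compound 3 `Cc1ccccc1C(=O)Nc1sc2c(c1C(N)=O)CCN(C(=S)Nc1ccccc1C(F)(F)F)C2` has not yet been measured. Compared with compound 2, the change is trifluoromethyl in place of bromo on an aromatic carbon. The same trifluoromethyl group is found in compound 1, which gives the lower number, but compound 1 also carries a different group on its benzamide, so this is only a loose hint. A step in this assay from compound 2 to compound 3 is expected to be modest and towards a lower number, about a 1.8-fold lower number from compound 2 to compound 3 (0.26 log units; within the scatter). For compound 3 the expected value in this assay is 25000 nM, with a range from 8000 nM to 70000 nM.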

Compound 3, half-maximal inhibitory concentration: 23200 nM
Beside the measured number, compound 3's estimate is 1.1-fold (0.03 log units) above it, and the stated range covers the measured number.
By their numbers in this assay, from the lowest: compound 1; then compounds 3 and 2 (each within the scatter of the next).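

With the rest of the molecule held constant, trifluoromethyl in place of bromo on the thiourea aryl group gives a 1.9-fold lower number from compound 2 to compound 3 (0.29 log units; within the scatter) in this assay, so this pair offers no firm sign that the choice between these two groups matters for the number at this position. For the compounds shown here, compound 3 also provides the first single-place comparison on the benzamide ring, where methyl in place of chloro on an aromatic carbon gives a 2.2-fold higher number from compound 1 to compound 3 (0.34 log units; beyond the scatter), a modest step that, unlike the thiourea aryl step, lies beyond the scatter. No measurement shown explains either result.

Whether the benzamide step would be repeated with bromo on the thiourea aryl group remains open, as the compounds shown give this step with trifluoromethyl alone. Going by these compounds alone, it is also unknown how this assay would respond to an amine or a carboxylic acid on the thiourea aryl group, since bromo and trifluoromethyl are the only two groups compared there, and these are too few to show a trend for this position.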